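The source may hold more compounds than are shown below. What is called first, only, known or untested is meant among the compounds shown, and "the series" means these compounds.

In a functional assay on BXPC-3 cells (Homo sapiens) for cytotoxicity, read by MTT assay, with a stated time of 72 h (a lower number here means a stronger inhibitor, a higher number a weaker inhibitor), two compounds sharing one core have been measured so far. Compound 1 `O=C1C(Nc2ccc(-c3ccc(Cl)cc3)cc2)=CC(=O)c2ncncc21` gives 10100 nM, while compound 2 `O=C1C(Nc2ccc(N3CCCCC3)cc2)=CC(=O)c2ncncc21` gives 2500 nM, the lower of the two numbers, and the gap between them lies beyond the scatter. Compound 3 `O=C1C(Nc2ccc(-c3cc(Cl)cc(Cl)c3)cc2)=CC(=O)c2ncncc21` has not yet been measured. It carries 3,5-dichlorophenyl in place of the piperidin-1-yl of compound 2 on an aromatic carbon: 3,5-dichlorophenyl in place of piperidin-1-yl on an aromatic carbon. Among the measured compounds shown here, one measured step bears on this change: a 4.0-fold lower number from compound 1 to compound 2 (0.61 log units; beyond the scatter). That modest step replaced the chlorine-bearing phenyl group of compound 1 with piperidin-1-yl at the same place. The change to compound 3 runs the opposite way, back to a chlorine-bearing phenyl group, so a step of similar size towards a higher number is expected in this assay. For the measured compounds named here, no measured compound shows what a second chlorine does, which leaves the expectation wide. The estimated step is a 3.2-fold higher number from compound 2 to compound 3 (0.51 log units; beyond the scatter). For compound 3 the expected value is 8000 nM, with an estimated range from 3000 nM to 20000 nM.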

Compound 3, half-maximal inhibitory concentration: 3300 nM
Compound 3: the middle estimate sits 2.4-fold (0.38 log units) above what was measured, within the range that was stated.
By their numbers in this assay, from the lowest: compounds 2 and 3 (each within the scatter of the next); then compound 1.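

In this assay, replacing piperidin-1-yl with 3,5-dichlorophenyl gives a 1.3-fold higher number from compound 2 to compound 3 (0.12 log units; within the scatter) and so leaves no readable difference between these two groups at this place, on an aromatic carbon para to a large group. The earlier step had set piperidin-1-yl apart from 4-chlorophenyl alone, whereas a 3.1-fold lower number from compound 1 to compound 3 (0.49 log units; beyond the scatter) shows that a chlorine-bearing phenyl group here need not give the higher number of compound 1, and that the arrangement of chlorine on the phenyl group can matter at this place. No measurement given here accounts for these numbers.

The compounds shown do not separate the effect of the second chlorine from that of moving chlorine away from the 4-position, a question that 3-chlorophenyl or unsubstituted phenyl would bear on. They also leave open whether other groups at this place, such as morpholin-4-yl, a dimethylamino group or a carboxylic acid, would give numbers in line with piperidin-1-yl and 3,5-dichlorophenyl or would move away from them in either direction.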